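Expanding a Ring on the Side Chain of Compound 1

This account rests on a few compounds, and the source may have more. Where it says the series, first, only, none or still open, it means among the compounds named here.

Compound 1 `FC(F)(F)c1cc(NC[C@H]2CCCN2)c2cn[nH]c2c1` carries a pyrrolidin-2-yl group on a saturated chain carbon bound to a nitrogen on an aromatic ring. In an assay for inhibition of Tryptophan 2,3-dioxygenase (Homo sapiens), with stated times of 10 min and 60 min (on this read-out higher numbers stand for weaker inhibition and lower numbers for stronger inhibition), compound 1 gives 6090 nM, the lowest of the two numbers available. Compound 3 `FC(F)(F)c1cccc(CNc2cc(C(F)(F)F)cc3[nH]ncc23)c1` gives 12200 nM in this assay, a value that lies within the scatter of compound 1, so the two cannot be ranked. For compound 2 `O=C1NCc2c(NCc3ccccc3[N+](=O)[O-])cccc21` the result is a limit of the assay rather than a number: > 100000 nM. Compound 4 `FC(F)(F)c1cc(NC[C@H]2CCCCN2)c2cn[nH]c2c1` has piperidin-2-yl in place of pyrrolidin-2-yl on a saturated chain carbon bound to a nitrogen on an aromatic ring. For the measured compounds named here, no measured pair shows this kind of change, so its direction is open; the expected step of a 1.1-fold higher number from compound 1 to compound 4 (0.06 log units; within the scatter) stays within the scatter. Compound 4 is therefore estimated at 7000 nM, with a range from 2000 nM to 25000 nM.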

Compound 4, half-maximal inhibitory concentration: 460 nM
Beside the measured number, compound 4's estimate is 15-fold (1.18 log units) above it; measured number outside the range, below it.
By their numbers in this assay, from the lowest: compound 4; then compounds 1 and 3 (each within the scatter of the next). At a limit, above all of these: compound 2.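

Placing piperidin-2-yl instead of pyrrolidin-2-yl on the side chain gives, in this assay, a 13-fold lower number from compound 1 to compound 4 (1.12 log units; beyond the scatter). For the compounds shown here, the earlier compounds offered no pair differing in one place, so this is the first evidence that this position responds strongly to a change from a five-membered to a six-membered ring. Nothing measured here explains why the six-membered ring gives the lower number.

On these data alone, whether a still larger azepan-2-yl ring would lower the number further remains open. So does the role of the ring nitrogen, which a tetrahydropyran-2-yl ring would test.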